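A few compounds are considered here, and "the series" means these few. Any claim that something is new, unique, unknown or untested is made for them only; others in the source may bear on it.

Measured so far in a functional assay on CHO cells for antagonist activity at Orexin receptor type 2 (Homo sapiens), read by FLIPR and calcium flux; a lower number here means a stronger inhibitor, a higher number a weaker inhibitor:
compound 1, `COc1ccc(C)cc1NC(=O)CSc1nnc(-c2ccoc2C)n1Cc1ccco1`, gives 15.9 nM.
compound 2, `Cc1occc1-c1nnc(SCC(=O)Nc2ccc(F)c(Cl)c2)n1Cc1ccco1`, gives 39.8 nM.

The two share one core and differ only in the ring on the amide nitrogen. For the measured compounds named here, compound 2 stands as the higher of the two numbers, the weaker inhibitor; the single measured step, a 2.5-fold higher number from compound 1 to compound 2 (0.40 log units; beyond the scatter), separates it from compound 1. Compound 3, `Cc1occc1-c1nnc(SCC(=O)Nc2ccc(F)cc2)n1Cc1ccco1`, is not yet measured. It differs from compound 2 in one place: hydrogen in place of chloro on an aromatic carbon. Going by the values given here, no measured step removes a single chloro from this ring; the measured step exchanged the whole ring at once, so it shows only that this ring matters modestly. Without a closer comparison, the expectation for a 1.6-fold higher number from compound 2 to compound 3 (0.20 log units; within the scatter) is a small shift, likely within the scatter or slightly beyond it toward a weaker inhibitor. Compound 3 is therefore estimated at 63 nM, with a range from 20 nM to 200 nM.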

Compound 3, inhibition constant: 158 nM
For compound 3 the middle estimate is 2.5-fold (0.40 log units) below the measured one, and the stated range covers the measured number.
By their numbers in this assay, from the lowest: compound 1; then compound 2; then compound 3.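

In this assay, the chloro on the 3-chloro-4-fluorophenyl ring matters on its own: replacing this one heavy atom with hydrogen, leaving 4-fluorophenyl, gives a clear loss (a 4.0-fold higher number from compound 2 to compound 3 (0.60 log units; beyond the scatter)). The ring on the amide nitrogen also has a wider reach than the first step showed, since the exchange of 2-methoxy-5-methylphenyl for 4-fluorophenyl spans a larger measured gap (a 9.9-fold higher number from compound 1 to compound 3 (1.00 log units; beyond the scatter)). Nothing available explains why this chloro counts.

The compounds shown leave open whether a bromo, a trifluoromethyl or a nitrile on the same aromatic carbon would match the chloro or give a lower number. They also leave open whether the chloro would count as much on a ring that has hydrogen in place of the fluoro.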